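This account rests on a few compounds, and the source may have more. Where it says the series, first, only, none or still open, it means among the compounds named here.

Measured compounds:
compound 1 `C#CCNC1CCc2c(OCc3cccc(C(F)(F)F)c3)cccc21` — 5410 nM
compound 2 `C#CCNC1CCc2c(SCc3cccc(F)c3)cccc21` — 11600 nM
compound 3 `C#CCNC1CCc2c(SCCc3ccc(Cl)cc3)cccc21` — 920 nM

All three values come from an ADME assay on isolated protein for inhibition of Amine oxidase [flavin-containing] B (Homo sapiens); a lower number here means a stronger inhibitor, a higher number a weaker inhibitor. Compound 3 gives the lowest number of the three. Compound 1 sits next, with a higher number, and compound 2 is furthest away, higher still; both gaps lie beyond the scatter, so compound 3 is the strongest inhibitor in this set on the present numbers. Among the measured compounds shown here, no pair among the measured compounds differs in a single place, so no step can be read off directly.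

Compound 4 `C#CCNC1CCc2c(SCCc3cccc(OC)c3)cccc21` has not yet been run in this assay. Against compound 3 it carries one change: 3-methoxyphenyl in place of 4-chlorophenyl on a saturated chain carbon, two bonds along the chain from a sulfur. For the measured compounds named here, there is no measured pair showing what this change does, so the expectation rests on the position of compound 3 alone, which gives 920 nM. The step from compound 3 to compound 4 is estimated to be a modest rise in the number, close to the edge of the scatter, a 2.2-fold higher number from compound 3 to compound 4 (0.34 log units; beyond the scatter). For compound 4 the value expected in this assay is 2000 nM, with a range from 700 nM to 6000 nM.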

Compound 4, half-maximal inhibitory concentration: 3820 nM
Compound 4: the middle estimate sits 1.9-fold (0.28 log units) below what was measured; the measured number falls inside the stated range.
By their numbers in this assay, from the lowest: compound 3; then compounds 4 and 1 (each within the scatter of the next); then compound 2.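

In this assay, among the compounds shown here, this is the first change that can be read in one place: 3-methoxyphenyl in place of 4-chlorophenyl on a saturated chain carbon, two bonds along the chain from a sulfur, gives a 4.2-fold higher number from compound 3 to compound 4 (0.62 log units; beyond the scatter), so the group held at this position matters to the read-out and this replacement weakens inhibition. For the compounds shown here, the entering group adds one heavy atom and one hydrogen-bond acceptor to the count, and compound 3 keeps the lowest number among the compounds measured so far. Nothing on record explains the step.

Because the substituent and its ring position change together here, this single step cannot assign the rise to either one, and 4-methoxyphenyl or 3-chlorophenyl at the same place would separate the two. Also open, as far as these compounds go, is how an unsubstituted phenyl, a longer chain between the sulfur and the ring, or an amine on the ring would behave at this position.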